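This account rests on a few compounds, and the source may have more. Where it says the series, first, only, none or still open, it means among the compounds named here.

Working notes on the series in a functional assay on the whole organism (Tail, strain ICR) with Mus musculus as the target, in the tail flick test, with a stated time of 120 min, at a dose of 25 umol/kg by the oral route; a lower number here means a weaker effect, a higher number a stronger effect of the compound at the dose given.

Compound 1, `N=C(N)NCCC[C@H](NC(=O)CN(c1nc(Cl)nc2[nH]cnc12)C1CC1)C(=O)O`, gives 17% in this assay. Compound 2, `N=C(N)NCCC[C@H](NC(=O)CN(c1nc(Cl)nc2[nH]cnc12)C1CC1)C(=O)OCc1ccccc1`, gives 10.2%, and compound 3, `O=C(OCc1ccccc1)[C@@H]1CCCN1C(=O)CN(c1ncnc2c1ncn2C1CCCCO1)C1CC1`, gives 17.5%. The three numbers all lie within the usual scatter of one another, so compound 1 sits with the other two and no ordering among them can be read from the data.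

Within the data shown here, the one measured step that changes a single place is a number 6.8 percentage points lower from compound 1 to compound 2 (within the scatter), a change on the oxygen next to the carbonyl group, far from the place now in question.

Compound 4, `O=C(O)CC[C@H](NC(=O)CN(c1nc(Cl)nc2[nH]cnc12)C1CC1)C(=O)O`, is not yet measured. It differs from compound 1 by a group of 3 heavy atoms (1 carbon, 2 oxygen; no ring) in place of a group of 5 heavy atoms (2 carbon, 3 nitrogen; no ring), on a saturated chain carbon, three bonds along the chain from an amide-type nitrogen and a carbonyl carbon.

Among the measured compounds shown here, no measured step touches this place or this kind of exchange, so nothing speaks for a shift beyond the scatter; the only single-place step, the one from compound 1 to compound 2, stayed within it. On that basis a step of about a number 1 percentage points lower from compound 1 to compound 4 (within the scatter) is expected, that is, none that the assay would resolve.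

Compound 4 is therefore estimated at 16% in this assay, with a range from 4% to 30%.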

Compound 4, a percentage reported as activity, at one dose (the size of the read-out at that dose, not a potency): 30.1%
Estimate against measurement, compound 4: 14.1 percentage points below; the whole stated range lies below it.
By their numbers in this assay, from the lowest: compounds 2, 1 and 3 (each within the scatter of the next); then compound 4.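

In this assay, among these compounds, carboxy in place of the group of 5 heavy atoms (2 carbon, 3 nitrogen; no ring), on a saturated chain carbon, three bonds along the chain from an amide-type nitrogen and a carbonyl carbon, gives a number 13.1 percentage points higher from compound 1 to compound 4 (beyond the scatter) and so marks this place as one where an exchange can be resolved, which no earlier step could show. Among the compounds shown here, the earlier single-place step, a number 6.8 percentage points lower from compound 1 to compound 2 (within the scatter) and at another place, gave no such resolved change, so this is the first step beyond the scatter, though it remains a modest one, read at a single dose and not a measure of potency. Nothing available bears on the cause of this step.

Open, on these data alone, is whether a primary amine, or a carboxylic acid on a shorter or longer chain, at this same place would keep, lose or enlarge the step. Also open, as far as these compounds go, is whether the step from the group of 5 heavy atoms to carboxy would hold at another dose or another stated time.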